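Replacing pyrrolidin-1-yl with ethyl: what to expect

The source may report more compounds than this note shows. Statements on the series, on what has been measured and on what is new or still open speak of the compounds shown alone.

Compound 1 `Cn1c(N)c(-c2nc3ccccc3[nH]2)c2nc(C#N)c(C#N)nc21`: > 50000 nM (a limit)
Compound 2 `N#Cc1nc2c(-c3nc4ccccc4[nH]3)c(N)n(CCN3CCCC3)c2nc1C#N`: > 50000 nM (a limit)
Compound 3 `CN1CCN(CCCn2c(N)c(-c3nc4ccccc4[nH]3)c3nc(C#N)c(C#N)nc32)CC1`: 5750 nM

All three values come from a functional assay on A549 cells (Homo sapiens) for antiproliferative activity, read by MTT assay, with a stated time of 48 h; on this read-out higher numbers stand for weaker inhibition and lower numbers for stronger inhibition. Compound 2 stands at > 50000 nM, which is a limit and not a number. Compound 1 shares that position, as the limit of > 50000 nM in this assay, at which 2 of the 3 values shown sit, shows.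

Compound 4 `CCCCn1c(N)c(-c2nc3ccccc3[nH]2)c2nc(C#N)c(C#N)nc21` has ethyl in place of pyrrolidin-1-yl on a saturated chain carbon, two bonds along the chain from an aromatic nitrogen.

Among the measured compounds shown here, three measured steps bear on this change. For the measured compounds named here, the first is a step that the two limits leave unreadable from compound 1 to compound 2. The two readable ones are an at least 8.6-fold lower number from compound 1 to compound 3 (0.93 log units; beyond the scatter) and an at least 8.6-fold lower number from compound 2 to compound 3 (0.93 log units; beyond the scatter). Going by the values given here, both end at compound 3, the only compound here with a 4-methylpiperazin-1-yl group. Compound 4 lacks that group, so no clear step is expected in this assay, and compound 4 should stay near the limit. The expected step is an at least 1.1-fold lower number from compound 2 to compound 4 (0.04 log units; that floor lies within the scatter). Compound 4 is estimated at 45000 nM, within an expected range of 15000 nM to 100000 nM.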

Compound 4, half-maximal inhibitory concentration: > 50000 nM
Compound 4 ended at the assay's limit; the forecaster's own chance of this, stated with the estimate: 65%; at least 1.1-fold (0.04 log units) between middle value and limit.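

In this assay, methyl in place of 4-methylpiperazin-1-yl on a saturated chain carbon, three bonds along the chain from an aromatic nitrogen, gives an at least 8.6-fold higher number from compound 3 to compound 4 (0.93 log units; beyond the scatter). Among the compounds shown here, this is the first comparison to show that a plain carbon chain of similar reach does not match compound 3, so chain length alone does not account for its measurable value, and compound 2, with its pyrrolidin-1-yl group, shows that a ring holding nitrogen is not enough either. The steps among compounds 1, 2 and 4 cannot be read, because all three sit at the same limit: the limit of > 50000 nM in this assay, at which 3 of the 4 values shown sit.

Going by these compounds, it remains open whether a morpholine ring in that place would keep the activity of compound 3. A longer chain carrying 4-methylpiperazin-1-yl is also untested among the compounds shown.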